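The source may report more compounds than this note shows. Statements on the series, on what has been measured and on what is new or still open speak of the compounds shown alone.

Measured so far in a functional assay on HTB-54 cells (Homo sapiens) for cytotoxicity, read by MTT assay, with a stated time of 72 h; a higher number here means a weaker inhibitor of growth, a lower number a stronger inhibitor of growth:
compound 1, `COc1ccc(CNc2nc([SeH])nc3ccccc23)cc1`, gives 7110 nM.
compound 2, `CCCCC[Se]c1nc([Se]CCCCC)c2ccccc2n1`, gives only a limit of the assay, > 100000 nM.
compound 3, `Sc1nc(NCc2ccccc2)c2ccccc2n1`, gives 15200 nM.

Of the two numbers, compound 3 has the higher; the nearest is compound 1, whose number is lower by an amount beyond the usual scatter. Compound 2 sits at the limit (the limit of > 100000 nM in this assay, at which 1 of the 3 values shown sits). The next member is compound 4, `[SeH]c1nc(NCc2ccccc2)c2ccccc2n1`, which differs from compound 3 by one selenium atom in place of one sulfur atom, on an aromatic carbon. Going by the values given here, no measured pair isolates this exchange; compound 1 already carries selenium yet differs from compound 3 elsewhere too, so its lower value cannot be assigned to that atom alone. In this assay a modest move toward lower numbers, or none beyond the scatter, is expected. For compound 4 the expected step is a 1.7-fold lower number from compound 3 to compound 4 (0.23 log units; within the scatter). Compound 4 is estimated to give 9000 nM, within 3500 nM to 25000 nM.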

Compound 4, concentration for 50% growth inhibition: 31200 nM
Compound 4: the middle estimate sits 3.5-fold (0.54 log units) below what was measured, and the stated range ends below it.
By their numbers in this assay, from the lowest: compound 1; then compound 3; then compound 4. At a limit, above all of these: compound 2.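

Selenium in place of sulfur on the aromatic carbon between two ring nitrogen atoms gives a 2.1-fold higher number from compound 3 to compound 4 (0.31 log units; beyond the scatter) in this assay, so this exchange at this position moves toward weaker growth inhibition. With selenium held constant, hydrogen in place of methoxy on an aromatic carbon gives a 4.4-fold higher number from compound 1 to compound 4 (0.64 log units; beyond the scatter), so the lower number of compound 1 goes with methoxy and not with selenium. No measured property here bears on either step.

Open, going by these compounds, is whether methoxy shifts the sulfur compound similarly, and whether an amine or a hydroxyl on this same aromatic carbon moves the number further.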